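Methyl on an aromatic carbon of compound 1

The source may report more compounds than this note shows. Statements on the series, on what has been measured and on what is new or still open speak of the compounds shown alone.

Measured so far:
Compound 1 (`O=C(Nc1nnn[nH]1)c1cc(=O)c2ccccc2o1`): 0.08 ug/mL
Compound 2 (`CN(C(=O)c1cc(=O)c2ccccc2o1)c1nnn[nH]1`): > 18 ug/mL (a limit)

Among the measured compounds shown here, in a functional assay on cells (Mast cell, Rattus norvegicus) for inhibition, with a stated time of 15 min (a higher number here means that more compound is needed for the effect, a lower number that less compound is needed), compound 1 gives 0.08 ug/mL, the only actual number so far. The one other result is a limit, so compound 1 cannot be ranked against a spread of values.

Compound 3 (`Cc1ccc2oc(C(=O)Nc3nnn[nH]3)cc(=O)c2c1`) is unmeasured and has methyl in place of hydrogen on an aromatic carbon.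

For the measured compounds named here, the only measured step is large: an at least 220-fold higher number from compound 1 to compound 2 (2.35 log units; beyond the scatter). Its size is bounded by the limit of > 18 ug/mL in this assay, at which 1 of the 2 values shown sits. That methyl sits on an amide-type nitrogen, not on an aromatic carbon, so it offers only weak guidance here. No step beyond the scatter is therefore expected in this assay, though a higher number remains the likelier risk.

The estimated value for compound 3 is 0.1 ug/mL, with an expected range of 0.02 ug/mL to 0.6 ug/mL. The expected step is a 1.3-fold higher number from compound 1 to compound 3 (0.10 log units; within the scatter).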

Compound 3, concentration for half-maximal effect: 0.075 ug/mL
For compound 3 the middle estimate is 1.3-fold (0.12 log units) above the measured one; the measured number falls inside the stated range.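

In this assay, the shared core accepts methyl in place of hydrogen on an aromatic carbon of the six-membered aromatic ring of carbon only, with a 1.1-fold lower number from compound 1 to compound 3 (0.03 log units; within the scatter). The same group on the amide-type nitrogen gives an at least 220-fold higher number from compound 1 to compound 2 (2.35 log units; beyond the scatter), so within these compounds the two places do not respond alike to an added methyl. For compound 2 the value is a limit and not a number, so that step has no exact size: the limit of > 18 ug/mL in this assay, at which 1 of the 3 values shown sits.

One methyl at one aromatic carbon does not show how a methoxy group, a chlorine atom or a carboxylic acid would fare at that place, or how methyl would fare at the other aromatic carbons of that ring. From the compounds shown here alone, whether an ethyl group or a longer chain on the amide-type nitrogen would behave like methyl also remains open.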